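Swapping tert-Butyl for Pyridinyl on the Amide Nitrogen

A few compounds are considered here, and "the series" means these few. Any claim that something is new, unique, unknown or untested is made for them only; others in the source may bear on it.

Of the compounds shown here, three sharing one core have been measured in an assay on HEK293 cells for agonist activity at transient receptor potential cation channel subfamily M member 8 (Homo sapiens), read by fluorescence and calcium flux, with a stated time of 15 min; a higher number here means that more compound is needed for the effect, a lower number that less compound is needed. Compound 1 `Cc1ccc(OCC(=O)N(Cc2cccs2)C2CCCCC2)cc1` carries a cyclohexyl group on the amide-type nitrogen and gives 40000 nM. Compound 2 `CON(Cc1cccs1)C(=O)COc1ccc(C)cc1` carries a methoxy group there and gives 10 nM. Compound 3 `Cc1ccc(OCC(=O)N(Cc2cccs2)C(C)(C)C)cc1` carries a tert-butyl group there and gives 11000 nM, the second highest of the three numbers; it sits nearest to compound 1 and furthest from compound 2.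

The step to compound 4 `Cc1ccc(OCC(=O)N(Cc2cccs2)c2ccncc2)cc1` changes the group on that nitrogen once more: pyridin-4-yl in place of tert-butyl on an amide-type nitrogen. The measured steps at this position are a 3.6-fold lower number from compound 1 to compound 3 (0.56 log units; beyond the scatter), a 4000-fold lower number from compound 1 to compound 2 (3.60 log units; beyond the scatter) and a 1100-fold higher number from compound 2 to compound 3 (3.04 log units; beyond the scatter). They show that the substituent on this nitrogen can move the result enormously, but none of them involves an aromatic ring, so the direction for compound 4 rests on thin ground. The cyclohexyl and tert-butyl groups gave high numbers and the methoxy group a very low one; a six-membered aromatic ring with one hydrogen-bond acceptor falls outside that comparison. Compound 4 is therefore expected to show a step of about a 3.7-fold lower number from compound 3 to compound 4 (0.56 log units; beyond the scatter) toward a lower number, with a wide range. The estimate for compound 4 in this assay is 3000 nM, between 300 nM and 30000 nM.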

Compound 4, half-maximal effective concentration: 52 nM
The estimate for compound 4 lay 58-fold (1.76 log units) above the measured number; measured number below the stated range.
By their numbers in this assay, from the lowest: compound 2; then compound 4; then compound 3; then compound 1.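

In this assay, within the data shown here, pyridin-4-yl is the first aromatic ring at this place on the amide-type nitrogen, and it brings a 210-fold lower number from compound 3 to compound 4 (2.33 log units; beyond the scatter) and a 770-fold lower number from compound 1 to compound 4 (2.89 log units; beyond the scatter), so a low number here does not belong to the methoxy group alone. Compound 2 still has the lowest number, with a 5.2-fold higher number from compound 2 to compound 4 (0.72 log units; beyond the scatter), but this step is modest beside the other two, and the four compounds now fall into two groups: the saturated carbon groups, tert-butyl and cyclohexyl, give high numbers, while the methoxy and pyridin-4-yl groups, which each contain a hetero atom, give low numbers, with no exception among these compounds. This pattern is only a description of four compounds, and no measurement is available that explains the effect of this change.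

The compounds shown leave open whether the aromatic ring or its ring nitrogen goes with the low number, a question that a plain phenyl group on the same amide-type nitrogen would help to settle. Also open, from the compounds shown here alone, is how pyridin-3-yl would compare with pyridin-4-yl, and whether an ethoxy group would keep the low number seen with methoxy.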